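The source may hold more compounds than are shown below. What is called first, only, known or untested is meant among the compounds shown, and "the series" means these compounds.

In a functional assay on HeLa cells (Homo sapiens) for cytotoxicity, read by WST assay, with a stated time of 48 h (on this read-out higher numbers stand for weaker inhibition and lower numbers for stronger inhibition), compound 2 `COc1cc(C(c2ccc(O)c(OC)c2)[C@@H](CO)C(C)C)ccc1O` gives > 100000 nM, which is a limit of the assay and not a number. Its exact position is therefore unknown, and any step that starts from it is uncertain in size. Compound 1 `COC[C@H](C)[C@@H](C)C(c1ccc(O)c(OC)c1)c1ccc(O)c(OC)c1`, by contrast, gives a true number of 77000 nM.

Compound 3 `COC[C@@H](C)[C@@H](C)C(c1ccc(O)c(OC)c1)c1ccc(O)c(OC)c1` has not yet been measured. The structural change leading to it is 2-(methoxymethyl)-1-methylpropyl in place of 1-(hydroxymethyl)-2-methylpropyl on a saturated chain carbon bound to two aromatic carbons. This places 2-(methoxymethyl)-1-methylpropyl, the group named in compound 1, on the saturated chain carbon bound to two aromatic carbons.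

Going by the values given here, only one measured step bears on this change: an at least 1.2-fold higher number from compound 1 to compound 2 (0.11 log units; that floor lies within the scatter). That step is the same exchange of groups run the other way, and its size is only a floor. A modest move to a lower number in this assay is therefore expected, meaning somewhat stronger inhibition, although a reading at the limit remains possible.

The expected step is an at least 1.3-fold lower number from compound 2 to compound 3 (0.12 log units; that floor lies within the scatter). For compound 3 the estimated value is 75000 nM, with an expected range of 35000 nM to 150000 nM.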

Compound 3, half-maximal inhibitory concentration: > 100000 nM
Compound 3 ended at the assay's limit; the forecaster's own chance of this, stated with the estimate: 30%; middle value at least 1.3-fold (0.12 log units) from the limit.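

In this assay compound 3 gives > 100000 nM, which is a limit and not a number, so the step linking it to compound 2, itself at a limit, cannot be read. The more informative comparison keeps the 2-(methoxymethyl)-1-methylpropyl group on the saturated chain carbon bound to two aromatic carbons and alters only one drawn stereocentre within it, giving an at least 1.2-fold higher number from compound 1 to compound 3 (0.11 log units; that floor lies within the scatter). This is the first view of configuration at this position, and it shows only a floor that does not establish a real difference, while a larger difference also remains possible: the fact that compounds 1 and 3 differ only in the configuration as drawn

As far as these compounds go, how far compound 3 truly lies from compound 1 remains open, as does the true position of compound 2. Also open, from the compounds shown here alone, is whether a different group on the saturated chain carbon bound to two aromatic carbons, such as one carrying an amine or a carboxylic acid, would give a reading clearly separated from that of compound 1.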